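Replacing the 3-Methylphenyl Group of Compound 2 on the Carbonyl

The source may report more compounds than this note shows. Statements on the series, on what has been measured and on what is new or still open speak of the compounds shown alone.

Compound 2 `Cc1ccc(-c2nn(-c3ccccc3)cc2-c2nc3ccccc3n2C(=O)c2cccc(C)c2)cc1` and compound 1 `Cc1ccc(-c2nn(-c3ccccc3)cc2-c2nc3ccccc3n2C(=O)c2ccccc2C)cc1` share one core and differ only in the group on the carbonyl carbon. In an ADME assay on HEK-293T cells (Homo sapiens) for cytotoxicity, read by MTT assay, with a stated time of 24 h (a lower number here means that less compound is tolerated, a higher number that more compound is tolerated), compound 2 gives 195000 nM, and in this assay compound 1 gives 176000 nM. Among the compounds with values here, the two numbers sit within the scatter of each other, so compound 2 does not stand apart from compound 1, and the one measured step, a 1.1-fold higher number from compound 1 to compound 2 (0.04 log units; within the scatter), tells of no change beyond the scatter when 3-methylphenyl takes the place of 2-methylphenyl on a carbonyl carbon.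

Compound 3 `Cc1ccc(-c2nn(-c3ccccc3)cc2-c2nc3ccccc3n2C(=O)c2cncc(C)c2)cc1` carries the next change: 5-methylpyridin-3-yl in place of 3-methylphenyl on a carbonyl carbon. Within the data shown here, the single measured step bears on it only in that it concerns the same carbonyl carbon; it does not touch an aromatic ring with a hetero atom, so the data give no direction for that part of the change. He therefore expects the step of a 1.0-fold lower number from compound 2 to compound 3 (0.01 log units; within the scatter) to stay within the scatter. His estimate for compound 3 in this assay is 190000 nM, with a range from 95000 nM to 380000 nM.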

Compound 3, half-maximal cytotoxic concentration: 155000 nM
The estimate for compound 3 lay 1.2-fold (0.09 log units) above the measured number; the measured number falls inside the stated range.
By their numbers in this assay, from the lowest: compounds 3, 1 and 2 (each within the scatter of the next).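

Within the data shown here, putting 5-methylpyridin-3-yl on the carbonyl carbon brings a six-membered aromatic ring with a hetero atom and a hydrogen-bond acceptor to this position for the first time, and in this assay the step stays within the scatter (a 1.3-fold lower number from compound 2 to compound 3 (0.10 log units; within the scatter)). Set against the 2-methylphenyl group, the same replacement also stays within the scatter (a 1.1-fold lower number from compound 1 to compound 3 (0.06 log units; within the scatter)), so all three groups on this carbonyl carbon now lie within the scatter of one another, and exchanging a ring carbon for a nitrogen adds nothing that this assay can separate from the earlier methyl shift. Nothing at hand bears on why the numbers stay so close, so the result stands as an observation only.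

All three compounds carry a methyl-bearing six-membered aromatic ring on the carbonyl carbon, so the compounds shown leave open whether an amine or a carboxylic acid on that ring would move the number beyond the scatter. They also leave open what a longer chain in place of the ring would do, or a ring without the methyl group.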